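Swapping fluoro for methyl on the amide-side phenyl ring

The compounds below may be only part of what the source reports. "The series", "measured", "known", "first", "only" and "open" are said of these compounds alone.

The three measured compounds share one core and differ only in the aryl group on the amide nitrogen. Compound 1 `Cc1ccc(NC(=O)c2cnn(-c3ccc(F)cc3)c2C)cc1` gives 540 nM in a functional assay with Homo sapiens as the target; a higher number here means a weaker inhibitor, a lower number a stronger inhibitor. Compound 2 `Cc1c(C(=O)Nc2cccc(F)c2)cnn1-c1ccc(F)cc1` gives 3000 nM, and compound 3 `Cc1c(C(=O)Nc2ccccc2F)cnn1-c1ccc(F)cc1` gives 4000 nM, the highest number of the three; its nearest neighbour is compound 2, within the scatter, while its furthest is compound 1, a gap shown by a 7.4-fold higher number from compound 1 to compound 3 (0.87 log units; beyond the scatter). Compound 4 `Cc1ccccc1NC(=O)c1cnn(-c2ccc(F)cc2)c1C` has not been measured. It differs from compound 3 by methyl in place of fluoro on an aromatic carbon.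

For the measured compounds named here, no measured step isolates this exact exchange. The closest guide is compound 1, whose 4-methylphenyl group gave a stronger result than either fluorophenyl, as a 5.6-fold higher number from compound 1 to compound 2 (0.74 log units; beyond the scatter) and a 7.4-fold higher number from compound 1 to compound 3 (0.87 log units; beyond the scatter) show, whereas a 1.3-fold higher number from compound 2 to compound 3 (0.12 log units; within the scatter) shows the two fluorophenyls close together. A modest move toward a lower number is therefore expected for compound 4, estimated at 2000 nM with a range of 600 nM to 6000 nM, corresponding to an expected step of a 2.0-fold lower number from compound 3 to compound 4 (0.30 log units; within the scatter).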

Compound 4, half-maximal inhibitory concentration: 1100 nM
Estimate against measurement, compound 4: 1.8-fold (0.26 log units) above, within the range that was stated.
By their numbers in this assay, from the lowest: compound 1; then compound 4; then compounds 2 and 3 (each within the scatter of the next).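

With the position on the ring held constant, the exchange of fluoro for methyl can now be read directly: in this assay it gives a 3.6-fold lower number from compound 3 to compound 4 (0.56 log units; beyond the scatter), so the group ortho to a large group changes the result on its own. The 2-methylphenyl group also stands apart from the 3-fluorophenyl group, with a 2.7-fold lower number from compound 2 to compound 4 (0.44 log units; beyond the scatter), although the two fluorophenyl compounds lie within the scatter of each other. Where the methyl sits matters as well, as a 2.0-fold higher number from compound 1 to compound 4 (0.31 log units; beyond the scatter) shows, and across these four compounds both methylphenyl groups give lower numbers than both fluorophenyl groups.

No measurement shown bears on why the number moves with these changes. Going by these compounds, whether a chlorine, a methoxy group or an amine at the same place would track with methyl or with fluoro stays open, as does the effect of a 3-methylphenyl group.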